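A few compounds are considered here, and "the series" means these few. Any claim that something is new, unique, unknown or untested is made for them only; others in the source may bear on it.

Compound 1 `ClCc1cccc(Cn2cnc3c(Cl)ncnc32)c1` and compound 2 `ClCc1cccc(Cn2cnc3c(Cl)nc(Cl)nc32)c1` share one core and differ in a single spot. In a functional assay on MDA-MB-231 cells (Homo sapiens) for cytotoxicity, read by sulforhodamine B assay, with a stated time of 48 h (a lower number here means that less compound is tolerated, a higher number that more compound is tolerated), compound 1 gives 8120 nM, and compound 2 gives 7240 nM. The change chloro in place of hydrogen on an aromatic carbon thus made a 1.1-fold lower number from compound 1 to compound 2 (0.05 log units; within the scatter). Compound 3 `ClCc1ccccc1Cn1cnc2ncnc(Cl)c21` is built from the same atoms as compound 1, joined differently; the difference between the two cores is not broken down here. In this assay compound 3 gives 25100 nM, the highest number of the three. Compound 4 `ClCc1ccccc1Cn1cnc2nc(Cl)nc(Cl)c21` has not yet been measured. It carries the same change as the one made earlier, namely (chloro in place of hydrogen on an aromatic carbon), now made on compound 3. Because the earlier instance gave a 1.1-fold lower number from compound 1 to compound 2 (0.05 log units; within the scatter), a step within the scatter, the expected step here is a 1.1-fold lower number from compound 3 to compound 4 (0.06 log units; within the scatter). Compound 4 is therefore estimated to give 22000 nM, most likely somewhere from 10000 nM to 50000 nM.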

Compound 4, concentration lethal to 50% of the cells: 3230 nM
Estimate against measurement, compound 4: 6.8-fold (0.83 log units) above, and the stated range ends above it.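

In this assay, chloro in place of hydrogen on an aromatic carbon, here between two ring nitrogen atoms, gives a 7.8-fold lower number from compound 3 to compound 4 (0.89 log units; beyond the scatter). The size of this step did not carry over from one core to the other: the same change on two cores in this assay, a 1.1-fold lower number (0.05 log units; within the scatter) from compound 1 to compound 2 and a 7.8-fold lower number (0.89 log units; beyond the scatter) from compound 3 to compound 4, 6.9-fold (0.84 log units) apart, beyond the scatter of two such steps. This shows that a step measured on one of these cores is a poor guide to the same change on the other, but it does not show why they differ, and one pair on each core gives no rule for any further core.

The compounds shown leave open how an amine or a methoxy group on that same carbon would compare with chloro on either core. They also leave open whether a third core would follow compound 2 or compound 4.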